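From pyridin-4-yl to pyridin-2-yl in compound 4

The source may hold more compounds than are shown below. What is called first, only, known or untested is meant among the compounds shown, and "the series" means these compounds.

Of the compounds shown here, three have values so far in a physicochemical assay for solubility, in phosphate buffer, at pH 7.4 (on this read-out higher numbers stand for higher solubility and lower numbers for lower solubility), and they stand as follows.
compound 1 (`Cn1cc(C(=O)Nc2ccc(-c3ccccc3)c(C(F)(F)F)c2)c(=O)c2ccccc21`) gives < 1 ug/mL (a limit)
compound 2 (`Cn1cc(C(=O)Nc2ccc(-c3cccnc3)c(C(F)(F)F)c2)c(=O)c2ccccc21`) gives < 1 ug/mL (a limit)
compound 3 (`Cn1cc(C(=O)Nc2ccc(-c3ccncc3)c(C(F)(F)F)c2)c(=O)c2ccccc21`) gives 7.9 ug/mL (a number)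

Compound 3 alone gives a true number and stands highest of the three at 7.9 ug/mL in this assay as measured. Compound 1 and compound 2 share one floor (the limit of < 1 ug/mL in this assay, at which 2 of the 3 values shown sit) and that is a limit, not a number.

Compound 4 (`Cn1cc(C(=O)Nc2ccc(-c3ccccn3)c(C(F)(F)F)c2)c(=O)c2ccccc21`) has the same atoms as compound 3, joined differently (pyridin-2-yl in place of pyridin-4-yl on an aromatic carbon) with pyridin-2-yl in place of pyridin-4-yl on an aromatic carbon, ortho to a trifluoromethyl group.

For the measured compounds named here, two measured steps bear on this change (an at least 7.9-fold higher number from compound 1 to compound 3 (0.89 log units; beyond the scatter) and an at least 7.9-fold higher number from compound 2 to compound 3 (0.89 log units; beyond the scatter)) and both lie beyond the scatter. The third (a step that the two limits leave unreadable from compound 1 to compound 2) gives no size. So far only pyridin-4-yl has left the limit, so the expectation in this assay is a fall beyond the scatter, about as large as the gain in an at least 7.9-fold higher number from compound 2 to compound 3 (0.89 log units; beyond the scatter) read backwards.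

For compound 4 the estimated value is 1 ug/mL with an expected range from 0.4 ug/mL to 4 ug/mL in this measurement. That estimate amounts to an expected 7.9-fold lower number from compound 3 to compound 4 (0.90 log units; beyond the scatter) if a number is reported at all.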

Compound 4, solubility: < 1 ug/mL
Compound 4: a limit, no number (the forecaster's own chance of this, stated with the estimate: 60%); the middle value sits exactly at the limit.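

Joining the same atoms differently at this place, ortho to a trifluoromethyl group, gives an at least 7.9-fold lower number from compound 3 to compound 4 (0.89 log units; beyond the scatter) in this assay, so pyridin-2-yl does not share the result seen with pyridin-4-yl. For the compounds shown here, with pyridin-3-yl in compound 2 and pyridin-2-yl in compound 4 both on the floor, pyridin-4-yl in compound 3 is now the only one of the four groups at this place to give a number: the limit of < 1 ug/mL in this assay, at which 3 of the 4 values shown sit. Compound 4 carries a limit and not a number, and its steps from compound 1 and compound 2 cannot be read, so phenyl, pyridin-3-yl and pyridin-2-yl cannot be ranked against one another.

As far as these compounds go, how far compound 1, compound 2 and compound 4 actually lie under the floor remains open, as does whether the result for pyridin-4-yl would hold with any other change to the shared core. Also open, from the compounds shown here alone, is whether an amine or a carboxylic acid carried on the pyridin-4-yl group would give a value different from that of compound 3 at 7.9 ug/mL.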